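The compounds below may be only part of what the source reports. "The series", "measured", "known", "first", "only" and "open" are said of these compounds alone.

Measured so far in a physicochemical assay for solubility, in phosphate buffer, at pH 7.4; on this read-out lower numbers stand for lower solubility and higher numbers for higher solubility:

- compound 1 `CC1(C)[C@H]2CC[C@]1(C)C(NC(=O)Nc1ccccc1F)C2` gives 225000 nM in this read-out
- compound 2 `O=C(NC1CC2C=CC1C2)N[C@H]1CC[C@H](Oc2ccc(C(=O)O)cc2)CC1` gives 350000 nM in this read-out

Compound 1 and compound 2 stand within the usual scatter of each other, so their two numbers cannot be told apart, although their structures differ in more than one place.

Compound 3 `CC1(C)[C@@H]2CC[C@@]1(C)C(NC(=O)Nc1ccccc1F)C2` has not yet been measured. Its difference from compound 1 is the two compounds have the same atoms and bonds; at least one stereo element is drawn with a configuration in one of them and without one in the other: 2 of 3 stereo elements differ; a stereocentre at a saturated ring carbon is drawn S in compound 1 and R in compound 3; a stereocentre at a saturated ring carbon is drawn S in compound 1 and R in compound 3 and so the two compounds have the same atoms and bonds, while stereocentres at saturated ring carbons drawn S in compound 1 are drawn R in compound 3.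

For the measured compounds named here, no measured pair here shows what a change of this kind does in this assay and the data offer no direct guide. With nothing to favour either direction, no step beyond the scatter is expected. The expected no change at the digits printed from compound 1 to compound 3 (within the scatter) is therefore no more than a shift within the scatter. For compound 3 the estimate is 225000 nM as the middle, with an expected range from 120000 nM to 420000 nM in this read-out.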

Compound 3, solubility: 225000 nM
Estimate against measurement, compound 3: no gap at the digits printed; low and high end bracket the measured number.
By their numbers in this assay, from the lowest: compounds 1, 3 and 2 (each within the scatter of the next).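

The pair of compound 1 and compound 3 gives this assay its first step between two compounds that differ in one kind of feature only, and that step reads no change at the digits printed from compound 1 to compound 3 (within the scatter). For the compounds shown here, with the atoms and bonds held in common, the two stereocentres at saturated ring carbons, drawn S in compound 1 and R in compound 3, make no difference that this read-out can resolve, which the earlier compounds could not show, as they offered no pair differing in one place. The step cannot be taken as a clean comparison of two fully defined forms because of one caution: the fact that one of compounds 1 and 3 is drawn with a defined configuration and the other without, at the place where they differ

The compounds shown leave open whether these stereocentres would count for as little if the core of compound 1 carried another group, such as an amine or a longer chain. They also leave open how a form with every stereo element defined would stand in this assay against compound 1 and compound 3.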